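This account rests on a few compounds, and the source may have more. Where it says the series, first, only, none or still open, it means among the compounds named here.

Measured so far in a functional assay on cells for antagonist activity at Free fatty acid receptor 1 (Homo sapiens), read by TR-FRET and inositol phosphate accumulation, with a stated time of 2 h; a lower number here means a stronger inhibitor, a higher number a weaker inhibitor:

- compound 1 `OC1CN(c2cc(COc3ccc(F)c(F)c3F)nc(-c3ccccn3)n2)C1`: 3160 nM
- compound 2 `Fc1ccc(OCc2cc(OCC3CCC3)nc(-c3ccccn3)n2)c(F)c1F`: 12.6 nM
- compound 3 `CC1(COc2cc(COc3ccc(F)c(F)c3F)nc(-c3ccccn3)n2)COC1`: 79.4 nM

Compound 3 sits second of the three numbers in this assay. Its nearest neighbour is compound 2, a 6.3-fold higher number from compound 2 to compound 3 (0.80 log units; beyond the scatter); the furthest is compound 1, a 40-fold lower number from compound 1 to compound 3 (1.60 log units; beyond the scatter). The larger steps in the set, a 250-fold lower number from compound 1 to compound 2 (2.40 log units; beyond the scatter) and the step just given from compound 1, both replace the whole 3-hydroxyazetidin-1-yl group, and so do not speak to a single-atom exchange within the oxetane.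

Compound 4 `Fc1ccc(OCc2cc(OCC3(F)COC3)nc(-c3ccccn3)n2)c(F)c1F` differs from compound 3 only by fluoro in place of methyl on a saturated ring carbon. For the measured compounds named here, no measured pair isolates such an exchange. Going by the values given here, the only comparison on the same chain carbon is cyclobutyl against 3-methyloxetan-3-yl, a modest step. Absent a direct precedent, the expected step of a 1.3-fold higher number from compound 3 to compound 4 (0.10 log units; within the scatter) is small, with the number for compound 4 expected close to that of compound 3 in this assay. Estimate for compound 4: 100 nM, range 30 nM to 320 nM.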

Compound 4, half-maximal inhibitory concentration: 63.1 nM
For compound 4 the middle estimate is 1.6-fold (0.20 log units) above the measured one; measured number inside the range.
By their numbers in this assay, from the lowest: compound 2; then compounds 4 and 3 (each within the scatter of the next); then compound 1.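

In this assay, for the compounds shown here, the first direct reading of this saturated ring carbon shows that 3-fluorooxetan-3-yl and 3-methyloxetan-3-yl cannot be told apart, with a 1.3-fold lower number from compound 3 to compound 4 (0.10 log units; within the scatter) for fluoro in place of methyl. The fluoro compound still falls short of the cyclobutyl group, with a 5.0-fold higher number from compound 2 to compound 4 (0.70 log units; beyond the scatter) for 3-fluorooxetan-3-yl in place of cyclobutyl, and it remains well clear of the 3-hydroxyazetidin-1-yl group, with a 50-fold lower number from compound 1 to compound 4 (1.70 log units; beyond the scatter) for the whole (3-fluorooxetan-3-yl)methoxy replacement. No measurement accompanies these numbers that could account for them, so they stand without an explanation.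

Going by these compounds, whether this ring carbon would tolerate a hydroxyl, an amine or a longer chain such as ethyl as it does methyl and fluoro remains open. Also open, on these data alone, is whether fluoro on the corresponding carbon of the cyclobutyl ring would give a comparable reading.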